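Hydrogen in place of fluoro in compound 3

This account rests on a few compounds, and the source may have more. Where it says the series, first, only, none or still open, it means among the compounds named here.

Within the data shown here, in a functional assay on MGC-803 cells (Homo sapiens) for inhibition, read by MTT assay, with a stated time of 48 h (a lower number here means a stronger inhibitor, a higher number a weaker inhibitor), compound 3 (`COc1ccc(CNc2cc(OC)c(OC)c(OC)c2)cc1F`) gives (39700 nM), the only true number among the three measured compounds. Compound 1 (`COc1cc(NCc2ccc(Cl)cc2)cc(OC)c1OC`) gives (> 80000 nM), which is a limit of the assay and not a number. Compound 2 (`COc1cc(NCc2ccc(Br)cc2)cc(OC)c1OC`) gives (> 80000 nM), which is likewise a limit.

Compound 4 (`COc1ccc(CNc2cc(OC)c(OC)c(OC)c2)cc1`) carries hydrogen in place of fluoro on an aromatic carbon, ortho to a methoxy group and meta to a large group (hydrogen in place of fluoro on an aromatic carbon). Among the measured compounds shown here, the one measured step between close relatives is (a step that the two limits leave unreadable from compound 1 to compound 2), where bromo replaces chloro. For the measured compounds named here, it offers no size to carry over, and no measured step involves fluoro. The only firm anchor is therefore compound 3 at (39700 nM), which lies close to (the limit of > 80000 nM in this assay, at which 2 of the 3 values shown sit). A report of compound 4 as a limit alone thus remains possible.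

Going by the values given here, with no measured step to suggest otherwise, no change beyond the usual scatter is expected in this assay, and any drift is expected to be slight and towards weaker inhibition. The estimated step is (a 1.1-fold higher number from compound 3 to compound 4 (0.05 log units; within the scatter)). Compound 4 is estimated at 45000 nM with an expected range from 20000 nM to 85000 nM in this estimate.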

Compound 4, half-maximal inhibitory concentration: 11400 nM
The estimate for compound 4 lay 3.9-fold (0.60 log units) above the measured number; measured number outside the range, below it.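

In this assay the place on the aromatic carbon ortho to a methoxy group and meta to a large group now gives its first readable step, and that step lies beyond the scatter: hydrogen in place of fluoro gives (a 3.5-fold lower number from compound 3 to compound 4 (0.54 log units; beyond the scatter)). So this position is not indifferent to the change, and here the compound without fluoro is the stronger of the pair. The comparisons with the halogen compounds add methoxy in place of bromo (an at least 7.0-fold lower number from compound 2 to compound 4 (0.84 log units; beyond the scatter)) and methoxy in place of chloro (an at least 7.0-fold lower number from compound 1 to compound 4 (0.84 log units; beyond the scatter)), but both start from a limit of the assay and so give a bound and not a size: (the limit of > 80000 nM in this assay, at which 2 of the 4 values shown sit).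

This single pair does not tell whether the gain belongs to the loss of fluoro in general or holds only alongside the methoxy group that compound 3 and compound 4 share. From the compounds shown here alone, what an amine, a hydroxyl or a larger group such as trifluoromethyl would do at the same place stays open, as does whether any of them would go beyond hydrogen.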